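A five-membered aromatic ring enters compound 1

A few compounds are considered here, and "the series" means these few. Any claim that something is new, unique, unknown or untested is made for them only; others in the source may bear on it.

In a functional assay on HOS-TE85 cells (Homo sapiens) for inhibition, read by CCK-8 assay, with a stated time of 72 h (on this read-out higher numbers stand for weaker inhibition and lower numbers for stronger inhibition), compound 1 (`COc1ccc(C)cc1N1C(=O)CSC1c1cccc(C(=O)NCCCCc2ccccc2)c1`) gives 300 nM, the higher of the two exact numbers in this small set. Compound 3 (`O=C(NCCCCc1ccccc1)c1cc(F)cc(C2SCC(=O)N2c2ccccn2)c1`) gives 14.2 nM, a clearly lower number, with the gap beyond the scatter. Compound 2 (`COc1ccccc1N1C(=O)CSC1C(=O)NCCCCc1ccccc1`) reads > 1000 nM, which is a limit of the assay and not a number.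

Compound 4 (`CC(C)(C)c1conc1N1C(=O)CSC1c1cccc(C(=O)NCCCCc2ccccc2)c1`) has not yet been measured. It departs from compound 1 at one place: a group of 9 heavy atoms (7 carbon, 1 nitrogen, 1 oxygen; one five-membered aromatic ring with 2 hetero atoms) in place of a group of 9 heavy atoms (8 carbon, 1 oxygen; one six-membered aromatic ring of carbon only), on an amide-type nitrogen in a ring. The 2-methoxy-5-methylphenyl group leaves the amide-type nitrogen in a ring, and a group with one five-membered aromatic ring with 2 hetero atoms enters.

Going by the values given here, no measured pair isolates this change. Compound 3, which also has a different group on that nitrogen, stands at 14.2 nM, but it differs elsewhere too, so it supports only a moderate expectation. In this assay a modest move toward stronger inhibition is expected, estimated as a 2.5-fold lower number from compound 1 to compound 4 (0.40 log units; beyond the scatter). For compound 4 the estimated value is 120 nM, with an expected range of 20 nM to 700 nM.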

Compound 4, half-maximal inhibitory concentration: > 1000 nM
Compound 4: only a limit was reported; the forecaster's own chance of this, stated with the estimate: 15%; at least 8.3-fold (0.92 log units) between middle value and limit.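

Placing this five-membered aromatic ring with 2 hetero atoms on the amide-type nitrogen in place of the 2-methoxy-5-methylphenyl group gives an at least 3.3-fold higher number from compound 1 to compound 4 (0.52 log units; beyond the scatter) in this assay. Going by these compounds alone, this is the first single-place comparison at this position, and it shows that the group on this nitrogen can weaken inhibition even when the count of heavy atoms stays the same. In this assay compound 4 reads > 1000 nM, which is a limit and not a number, so the step gives only a minimum size, and the full gap stays unknown: the limit of > 1000 nM in this assay, at which 2 of the 4 values shown sit.

The compounds shown do not separate the effect of the ring itself from that of the substituent it carries. They also leave open how a plain phenyl or a cyclohexyl group on this nitrogen would read in this assay.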